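The source may report more compounds than this note shows. Statements on the series, on what has been measured and on what is new or still open speak of the compounds shown alone.

Measured compounds:
Compound 1, `Cn1nc2c(=O)n(CC3(O)CCN(Cc4ccc(-c5ccsc5)cc4Cl)CC3)cnc2c1-c1ccc(CN)cc1`, gives 59.5 nM in an assay on isolated protein for inhibition of ubiquitin carboxyl-terminal hydrolase 7 (Homo sapiens), with stated times of 30 min and 2 h; a lower number here means a stronger inhibitor, a higher number a weaker inhibitor.
Compound 2, `Cn1nc2c(=O)n(CC3(O)CCN(Cc4ccc(-c5ccco5)cc4Cl)CC3)cnc2c1-c1ccc(C(=N)N)cc1`, gives 87.5 nM in this assay.

Only two compounds have been measured in this assay, and compound 2 stands with compound 1 inside the usual scatter, so the two cannot be separated on the numbers shown. Among the measured compounds shown here, no step between measured compounds is available.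

Compound 3, `Cn1nc2c(=O)n(CC3(O)CCN(Cc4ccc(-c5ccco5)cc4Cl)CC3)cnc2c1-c1ccc(CN)cc1`, is the next compound to be measured. It differs from compound 2 in one place: a group of 2 heavy atoms (1 carbon, 1 nitrogen; no ring) in place of a group of 3 heavy atoms (1 carbon, 2 nitrogen; no ring), on an aromatic carbon. The same aminomethyl group already appears in compound 1, whose value in this assay is 59.5 nM, while the other part of the molecule in compound 3 matches compound 2.

Because compound 1 gives 59.5 nM and compound 2 gives 87.5 nM, which lie within the scatter of each other, the step is expected to be small, with no direction beyond the scatter: a 1.3-fold lower number from compound 2 to compound 3 (0.13 log units; within the scatter). Compound 3 is estimated at 65 nM, with a range from 30 nM to 140 nM.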

Compound 3, half-maximal inhibitory concentration: 18.1 nM
The estimate for compound 3 lay 3.6-fold (0.56 log units) above the measured number, outside the stated range (below it).
By their numbers in this assay, from the lowest: compound 3; then compounds 1 and 2 (each within the scatter of the next).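

In this assay, with everything else held fixed, aminomethyl in place of the group of 3 heavy atoms, on an aromatic carbon para to a large group, gives a 4.8-fold lower number from compound 2 to compound 3 (0.68 log units; beyond the scatter), so the number responds to the group at this position. With aminomethyl held fixed, furan-2-yl in place of thiophen-3-yl gives a 3.3-fold lower number from compound 1 to compound 3 (0.52 log units; beyond the scatter), so the values of compound 1 and compound 2, which differ in two places and lie within the scatter of each other, concealed two separate steps. Nothing shown gives an explanation for either step.

The compounds shown leave open how a longer chain such as aminoethyl, or a hydroxymethyl, would compare with aminomethyl at this position. They also leave open whether thiophen-2-yl would stand with furan-2-yl or with thiophen-3-yl.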